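The source may report more compounds than this note shows. Statements on the series, on what has been measured and on what is new or still open speak of the compounds shown alone.

Measured in a functional assay on MGC-803 cells (Homo sapiens) for inhibition, read by CCK-8 assay, with a stated time of 48 h; a higher number here means a weaker inhibitor, a lower number a stronger inhibitor:
- compound 1 `COc1ccc(CN(C(=O)CSc2nc3ccccc3o2)c2cc(OC)c(OC)c(OC)c2)cc1`: 450 nM
- compound 2 `COc1ccc(CN(C(=O)CSC(=S)N2CCN(C)CC2)c2cc(OC)c(OC)c(OC)c2)cc1`: 1280 nM
- compound 3 `COc1ccc(CN(C(=O)CSC(=S)N2CCN(C(C)=O)CC2)c2cc(OC)c(OC)c(OC)c2)cc1`: 480 nM

Compound 3 belongs to the lower pair of the three numbers, with a 1.1-fold higher number from compound 1 to compound 3 (0.03 log units; within the scatter) and a 2.7-fold lower number from compound 2 to compound 3 (0.43 log units; beyond the scatter). Compound 4 `COc1ccc(CN(C(=O)CSC(=S)N2CCCC2)c2cc(OC)c(OC)c(OC)c2)cc1` differs from it by one change on a thiocarbonyl carbon: pyrrolidin-1-yl in place of 4-acetylpiperazin-1-yl on a thiocarbonyl carbon. For the measured compounds named here, no measured step makes this exact exchange. The nearest evidence is a 2.7-fold lower number from compound 2 to compound 3 (0.43 log units; beyond the scatter), where only the group on the ring amine nitrogen changes, and a 2.8-fold higher number from compound 1 to compound 2 (0.45 log units; beyond the scatter), which is of similar size. Both steps are modest, so a modest step is expected in this assay, with the direction uncertain but leaning towards a higher number. The expected step is a 1.5-fold higher number from compound 3 to compound 4 (0.16 log units; within the scatter). For compound 4 the estimated value is 700 nM, with an expected range of 280 nM to 1800 nM.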

Compound 4, half-maximal inhibitory concentration: > 20000 nM
Compound 4 was reported as a limit; the forecaster's own chance of this, stated with the estimate: 3%; middle value at least 28-fold (1.45 log units) away from the limit.
By their numbers in this assay, from the lowest: compounds 1 and 3 (each within the scatter of the next); then compound 2. At a limit, above all of these: compound 4.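

Compound 4 is reported only as a limit, not a number: the limit of > 20000 nM in this assay, at which 1 of the 4 values shown sits.

On the thiocarbonyl carbon, pyrrolidin-1-yl in place of 4-acetylpiperazin-1-yl gives an at least 41-fold higher number from compound 3 to compound 4 (1.61 log units; beyond the scatter), and in place of 4-methylpiperazin-1-yl it gives an at least 15-fold higher number from compound 2 to compound 4 (1.19 log units; beyond the scatter). For the compounds shown here, both are large, whereas the earlier steps were modest or within the scatter, and the comparison on sulfur gives an at least 44-fold higher number from compound 1 to compound 4 (1.64 log units; beyond the scatter), so the group at this position can decide whether the series keeps its activity.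

As far as these compounds go, whether the loss goes with the five-membered ring or with the absent second ring nitrogen remains open. Piperidin-1-yl or morpholin-4-yl on the thiocarbonyl carbon would separate the two.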